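Hemolysis inhibition series: step from compound 2 to compound 4

The source may hold more compounds than are shown below. What is called first, only, known or untested is meant among the compounds shown, and "the series" means these compounds.

Measured compounds:
compound 1 `COc1cc(OC)c(OC)cc1/C=C/C(=O)c1cc(OC(C)=O)ccc1OC(C)=O`, 2.33 ug/mL
compound 2 `COc1cc(OC)c(OC)cc1/C=C/C(=O)c1cc(Cl)ccc1O`, 2.23 ug/mL
compound 3 `COc1cc(OC)c(C(=O)/C=C/c2cc(OC)c(OC)cc2OC)c(OC)c1`, 2.13 ug/mL

The three measured compounds were run in a functional assay on cells (Erythrocyte, Rattus norvegicus) for inhibition, read by hemolysis, with a stated time of 1 h; on this read-out higher numbers stand for weaker inhibition and lower numbers for stronger inhibition. In this assay compound 1 gives 2.33 ug/mL, compound 2 gives 2.23 ug/mL and compound 3 gives 2.13 ug/mL. Compound 2 sits within the scatter of both compound 1 and compound 3, so the three numbers cannot be told apart; the series shows no resolved trend so far.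

Compound 4 `COc1cc(OC)c(OC)cc1/C=C/C(=O)c1ccccc1` is not yet measured. It differs from compound 2 by phenyl in place of 5-chloro-2-hydroxyphenyl on a carbonyl carbon. The change removes the hydrogen-bond donor and the hydrogen-bond acceptor of the leaving group, and the chlorine with them, so the carbonyl carbon now carries an unsubstituted phenyl. For the measured compounds named here, no measured pair isolates a change of this kind, so the size of its effect is unknown.

The expected step of a 1.4-fold higher number from compound 2 to compound 4 (0.16 log units; within the scatter) is small, toward a higher number, and may well stay within the scatter. Compound 4 is estimated to give 3.2 ug/mL, with a range from 1.3 ug/mL to 8 ug/mL.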

Compound 4, half-maximal inhibitory concentration: 2.23 ug/mL
Estimate against measurement, compound 4: 1.4-fold (0.16 log units) above; low and high end bracket the measured number.
By their numbers in this assay, from the lowest: compounds 3, 2, 4 and 1 (each within the scatter of the next).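

For the compounds shown here, the first one-place comparison in this assay reads no change at the digits printed from compound 2 to compound 4 (within the scatter) when the 5-chloro-2-hydroxyphenyl group is replaced by phenyl. This position therefore tolerates losing the chlorine, the hydrogen-bond donor and the hydrogen-bond acceptor of the leaving group in a single change, with no resolved shift in this read-out, so none of these features is shown to be needed for the activity of compound 2. No measured information on the compounds bears on why this result comes out as it does.

Going by these compounds alone, since all of these features leave together, it remains open whether a 5-chlorophenyl or a 2-hydroxyphenyl group alone would read the same as phenyl, or whether opposing contributions cancel in the single step. As far as these compounds go, it also remains open whether a different kind of group on this ring, such as an amine or a carboxylic acid, would move the number beyond the scatter, or whether the position stays as flat as this one comparison suggests.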